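Swapping the Halogenated Aniline Ring for an Ethyl-Bearing One

The compounds below may be only part of what the source reports. "The series", "measured", "known", "first", "only" and "open" are said of these compounds alone.

Measured so far in a functional assay on A-431 cells (Homo sapiens) for antiproliferative activity, read by MTT assay, with a stated time of 72 h; on this read-out higher numbers stand for weaker inhibition and lower numbers for stronger inhibition:
compound 1 `COc1cc2ncnc(Nc3cccc(F)c3)c2cc1OCCCCC(=O)Nc1ccc(S(N)(=O)=O)cc1` gives 29900 nM
compound 2 `COc1cc2ncnc(Nc3cccc(Cl)c3F)c2cc1OCCCCC(=O)Nc1ccc(S(N)(=O)=O)cc1` gives 5560 nM

Compound 2 stands lowest of the two numbers in this assay; the gap up to the other compound, a 5.4-fold lower number from compound 1 to compound 2 (0.73 log units; beyond the scatter), lies beyond the scatter. Compound 3 `CCc1ccc(Nc2ncnc3cc(OC)c(OCCCCC(=O)Nc4ccc(S(N)(=O)=O)cc4)cc23)cc1` is not yet measured. It differs from compound 2 in one place: 4-ethylphenyl in place of 3-chloro-2-fluorophenyl on a nitrogen on an aromatic ring. Within the data shown here, the single measured step, a 5.4-fold lower number from compound 1 to compound 2 (0.73 log units; beyond the scatter), exchanged one halogen-bearing ring for another halogen-bearing ring, so it does not bear directly on trading halogens for an ethyl group; it shows only that the ring on the nitrogen can shift the number well beyond the scatter. Among the measured compounds shown here, with no step covering this kind of change, the direction remains open and the uncertainty is wide. Compound 3 is therefore estimated at 12000 nM, within 3000 nM to 45000 nM. That estimate means an expected step of a 2.2-fold higher number from compound 2 to compound 3 (0.33 log units; beyond the scatter).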

Compound 3, half-maximal inhibitory concentration: 7220 nM
Beside the measured number, compound 3's estimate is 1.7-fold (0.22 log units) above it; the measured number falls inside the stated range.
By their numbers in this assay, from the lowest: compounds 2 and 3 (each within the scatter of the next); then compound 1.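

In this assay, the ring on the nitrogen can carry an ethyl group and no halogen at all and still stay within the scatter of compound 2, with a 1.3-fold higher number from compound 2 to compound 3 (0.11 log units; within the scatter) for the exchange of 3-chloro-2-fluorophenyl for 4-ethylphenyl. A halogen on this ring is therefore not required to reach that level among these compounds, and the 4-ethylphenyl ring also stands clear of the 3-fluorophenyl ring, with a 4.1-fold lower number from compound 1 to compound 3 (0.62 log units; beyond the scatter) as the step. No measurement offered here explains why these rings give the numbers they do.

All three rings shown carry only halogens or an ethyl group, so the effect of an amine, a methoxy group or a carboxylic acid on this ring remains open. Also open, as far as these compounds go, is whether a methyl or a longer chain in place of the ethyl group would give a similar number.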